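Chloro to methoxy, carried from one core to another

The source may report more compounds than this note shows. Statements on the series, on what has been measured and on what is new or still open speak of the compounds shown alone.

Compound 1 `Cc1cc(C)c2c(O)cc(-c3ccc(Cl)cc3)nc2n1` and compound 2 `COc1ccc(-c2cc(O)c3c(C)cc(C)nc3n2)cc1` share one core; compound 3 `Cc1cnc2nc(-c3ccc(Cl)cc3)cc(O)c2c1` is built on a different core, and compound 4 `COc1ccc(-c2cc(O)c3cc(C)cnc3n2)cc1` is built on the core of compound 3. In a functional assay on PC-3 cells (Homo sapiens) (a higher number here means a weaker inhibitor of growth, a lower number a stronger inhibitor of growth), compound 1 gives 6310 nM, compound 2 gives 24000 nM and compound 3 gives 1150 nM. Compound 3 stands lowest of the three measured values, with compound 1 nearest and compound 2 furthest from it. The difference between the core of compound 3 and the core of compound 1 is not broken down here.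

The change from compound 1 to compound 2 is methoxy in place of chloro on an aromatic carbon. In this assay it gave a 3.8-fold higher number from compound 1 to compound 2 (0.58 log units; beyond the scatter). The change from compound 3 to compound 4 is methoxy in place of chloro on an aromatic carbon, the same change at the same kind of place, now on the core of compound 3. Within this set it has been measured once only, and on the other core, so how far it carries over is not known.

For compound 4 the step is expected to be a 3.8-fold higher number from compound 3 to compound 4 (0.58 log units; beyond the scatter). For the measured compounds named here, this expectation rests on the one measured instance of the change, a 3.8-fold higher number from compound 1 to compound 2 (0.58 log units; beyond the scatter), applied to compound 3 as the starting point. As far as these compounds go, compound 4 is therefore estimated at 4400 nM in this assay, with a range from 1800 nM to 11000 nM that is kept wide since the transfer between cores is untested.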

Compound 4, concentration for 50% growth inhibition: 5370 nM
The estimate for compound 4 lay 1.2-fold (0.09 log units) below the measured number, and the stated range covers the measured number.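

On the second core, methoxy in place of chloro gave a 4.7-fold higher number from compound 3 to compound 4 (0.67 log units; beyond the scatter) in this assay, in the same direction as on the first core. Set side by side, the two steps do not differ: the same change on two cores in this assay, a 3.8-fold higher number (0.58 log units; beyond the scatter) from compound 1 to compound 2 and a 4.7-fold higher number (0.67 log units; beyond the scatter) from compound 3 to compound 4, 1.2-fold (0.09 log units) apart, within the scatter of two such steps. This shows that, for these two cores in this assay, the step measured on one core carried over to the other in both direction and size, though it rests on just two pairs and shows neither that it would hold on a further core nor why methoxy gives the higher number.

As far as these compounds go, both pairs compare only chloro and methoxy at one place, on an aromatic carbon of a six-membered aromatic ring of carbon only, para to a large group, so it remains open whether an amine, a carboxylic acid or a longer chain at that place would behave alike on both cores. Also open is whether the agreement extends to growth inhibition in other cell lines, and how the two cores compare in their own right, since no step shown here isolates the difference between them.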